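A few compounds are considered here, and "the series" means these few. Any claim that something is new, unique, unknown or untested is made for them only; others in the source may bear on it.

Measured so far in a functional assay on the whole organism (strain C57B/6) with Mus musculus as the target, in the maximal electroshock model; on this read-out lower numbers stand for an effect already at smaller amounts and higher numbers for an effect only at larger amounts of compound:
- compound 1 `CCCCCCOc1ccc(-n2cnnc2CCCC)cc1`: 13.6 mg/kg
- compound 2 `CCCCCCCc1nncn1-c1ccc(OCCCCCC)cc1`: > 40 mg/kg (a limit of the assay, not a number)

Compound 2 stands at the limit of this assay (the limit of > 40 mg/kg in this assay, at which 1 of the 2 values shown sits), so only a bound is known for it, not a value. Within the data shown here, the one measured step that bears on chain length is an at least 2.9-fold higher number from compound 1 to compound 2 (0.46 log units; beyond the scatter): the longer chain moved the read-out toward higher numbers, past the range the assay reports.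

Compound 3 `CCCCCCCCCc1nncn1-c1ccc(OCCCCCC)cc1` differs from compound 2 by ethyl in place of hydrogen on a saturated chain carbon, seven bonds along the chain from an aromatic carbon, that is, by a further lengthening of the same chain. On the evidence of the step from compound 1 to compound 2, a further increase of the number, or at best no change beyond the scatter, is expected; the expected step is a step that the limit leaves unreadable from compound 2 to compound 3. Compound 3 is therefore expected to give about 70 mg/kg, estimated between 30 mg/kg and 200 mg/kg, most likely reported again only as a limit.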

Compound 3, dose for half-maximal effect: > 40 mg/kg
Compound 3: no number, only a limit (the forecaster's own chance of this, stated with the estimate: 80%); the middle value is on the limit's open side.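

In this assay compound 3 gives > 40 mg/kg, which is a limit of the assay and not a number. The step between compound 2 and compound 3 cannot be read, because both stand at the same limit: the limit of > 40 mg/kg in this assay, at which 2 of the 3 values shown sit.

What compound 3 adds is an at least 2.9-fold higher number from compound 1 to compound 3 (0.46 log units; beyond the scatter) and so the move toward higher numbers seen with propyl at that place remains with this longer addition.

From the compounds shown here alone, how far compound 2 and compound 3 lie past the limit stays unknown, so no order between them can be given. Also open, going by these compounds, is whether an amine or a carboxylic acid in place of the added chain would bring the number back down in this assay.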